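The source may hold more compounds than are shown below. What is called first, only, known or untested is meant among the compounds shown, and "the series" means these compounds.

In an ADME assay on PANC-1 cells (Homo sapiens) for cytotoxicity, read by MTT assay (on this read-out lower numbers stand for higher toxicity in this test and higher numbers for lower toxicity in this test), compound 1, with the structure `Cc1nc(-c2cccnc2)sc1-c1nnc(-c2ccccc2)o1`, reaches only the assay's limit and gives > 100 ug/mL. Compound 2, with the structure `Cc1nc(-c2cccnc2)sc1-c1nnc(-c2cccc(Cl)c2Cl)o1`, likewise stays at the limit in this assay and gives > 100 ug/mL. Compound 2 therefore stands at the limit of > 100 ug/mL in this assay, at which 2 of the 2 values shown sit, so no number is attached to it, only a boundary. Compound 3, with the structure `Cc1ccc(-c2nnc(-c3sc(-c4cccnc4)nc3C)o2)cc1`, differs from compound 2 by 4-methylphenyl in place of 2,3-dichlorophenyl on an aromatic carbon. Among the compounds with values here, the only measured step that bears on this kind of change is a step that the two limits leave unreadable from compound 1 to compound 2, and because both of its ends sit at the limit of > 100 ug/mL in this assay, at which 2 of the 2 values shown sit, it cannot tell how large the step was. For this assay the expected step is a step that the limit leaves unreadable from compound 2 to compound 3, with no direction that the data can support. On that basis compound 3 is expected to give about 120 ug/mL, within a range from 50 ug/mL to 300 ug/mL, and most likely to land again at the limit.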

Compound 3, half-maximal cytotoxic concentration: > 100 ug/mL
Compound 3: only a limit was reported; the forecaster's own chance of this, stated with the estimate: 80%; the middle value is on the limit's open side.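

Within the data shown here, compound 3 also gives only a limit, not a number, so no step among compound 1, compound 2 and compound 3 can be read: the limit of > 100 ug/mL in this assay, at which 3 of the 3 values shown sit. The compounds shown leave open whether phenyl, 2,3-dichlorophenyl and 4-methylphenyl differ at all in this assay.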